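This account rests on a few compounds, and the source may have more. Where it says the series, first, only, none or still open, it means among the compounds named here.

Compound 1 `COc1ccc(NC(=O)/C=C/c2ccccc2C(F)(F)F)cc1OC`: > 200000 nM
Compound 2 `COc1ccccc1NC(=O)/C(C#N)=C/c1ccccc1C(F)(F)F`: > 200000 nM
Compound 3 `N#C/C(=C\c1ccccc1C(F)(F)F)C(=O)Nc1ccc(F)c(Cl)c1`: > 200000 nM

All three were tested in an ADME assay on HBZY-1 cells (Rattus norvegicus) for cytotoxicity, read by MTT assay, with a stated time of 2 h (a higher number here means a weaker inhibitor, a lower number a stronger inhibitor), and none gave a number. Compound 3 gives > 200000 nM, which is a limit of the assay and not a measured value. Compound 4 `COc1ccc(NC(=O)/C(C#N)=C/c2ccccc2C(F)(F)F)cc1` differs from compound 3 by 4-methoxyphenyl in place of 3-chloro-4-fluorophenyl on an amide-type nitrogen. Going by the values given here, the only measured step at this place is a step that the two limits leave unreadable from compound 2 to compound 3, so it offers no size to carry over. Because the limit of > 200000 nM in this assay, at which 3 of the 3 values shown sit, applies across the series, no step beyond the scatter is expected in this assay, and no direction can be favoured. The expected step is a step that the limit leaves unreadable from compound 3 to compound 4. For compound 4 the estimated value is 300000 nM, with an expected range from 120000 nM to 600000 nM.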

Compound 4, half-maximal inhibitory concentration: > 200000 nM
Compound 4: only a limit was reported (the forecaster's own chance of this, stated with the estimate: 85%); the middle value is on the limit's open side.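

The steps from compound 2 to compound 4 and from compound 3 to compound 4 cannot be read, as each compound reaches only a limit in this assay: the limit of > 200000 nM in this assay, at which 4 of the 4 values shown sit.

The compounds shown leave open whether the group on the amide-type nitrogen changes the result in this assay at all.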